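The source may report more compounds than this note shows. Statements on the series, on what has been measured and on what is new or still open speak of the compounds shown alone.

Working notes on the series. Two compounds have numbers in an ADME assay on HepG2 cells (Homo sapiens) for cytotoxicity, with a stated time of 72 h; on this read-out higher numbers stand for weaker inhibition and lower numbers for stronger inhibition. Compound 1, `CCCCCCc1ccc(-c2ccc(C(=O)N[C@@H](CCCN)C(=O)N[C@H](C(=O)N[C@@H](C)C(=O)N[C@@H](CC(N)=O)C(=O)N[C@@H](C)B(O)O)[C@@H](C)O)cc2)cc1`, the open-chain member, gives 10100 nM in this assay. Compound 2, `CCCCCCc1ccc(-c2ccc(C(=O)N[C@@H](CCCN)C(=O)N[C@H](C(=O)N[C@@H](C)C(=O)N[C@H]3Cc4cn(nn4)CCO[C@@H]4C[C@@H]5OB(O[C@@H]5C4)[C@H](C)NC3=O)[C@@H](C)O)cc2)cc1`, the macrocyclic member, gives 8000 nM in this assay. For the measured compounds named here, compound 2 is one of two compounds measured and its number sits alongside that of compound 1, the gap between the two within the scatter, so the pair shows nothing beyond that.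

Compound 3, `C[C@@H]1NC(=O)[C@@H](NC(=O)[C@H](C)NC(=O)[C@@H](NC(=O)[C@H](CCCN)NC(=O)c2ccc(-c3ccccc3)cc2)[C@@H](C)O)Cc2cn(nn2)CCO[C@@H]2C[C@@H]3OB1O[C@@H]3C2`, is not yet measured. It differs from compound 2 in one place: hydrogen in place of hexyl on an aromatic carbon. Going by the values given here, no measured pair carries this change, so nothing in the present numbers tells how this assay answers it.

Expectation: the step from compound 2 to compound 3 in this assay is estimated as a 2.0-fold higher number from compound 2 to compound 3 (0.30 log units; within the scatter), a modest move toward a higher number, with no change beyond the scatter also well within what is allowed. On that basis compound 3 is expected to give about 16000 nM in this assay, with the likely range running from 6000 nM to 45000 nM.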

Compound 3, half-maximal inhibitory concentration: > 64000 nM
Compound 3 was reported as a limit; the forecaster's own chance of this, stated with the estimate: 25%; at least 4.0-fold (0.60 log units) between middle value and limit.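

For the compounds shown here, replacing 4-hexylphenyl with phenyl gives the first step at this position in this assay, and that step, an at least 8.0-fold higher number from compound 2 to compound 3 (0.90 log units; beyond the scatter), is beyond the scatter. This position therefore matters in this read-out: with hexyl on the aromatic carbon, compound 2 has a measured number, whereas with hydrogen there, compound 3 has only a limit. The value of compound 3 is a limit and not a number, so the printed step gives only the smallest size of the change, not its full size: the limit of > 64000 nM in this assay, at which 1 of the 3 values shown sits.

The compounds shown hold nothing between hexyl and hydrogen at this place, so it remains open whether a shorter chain such as propyl or a longer chain such as octyl would give a number that tracks chain length, and whether an amine or a carboxylic acid at the end of such a chain would give a similar number. Also open, from the compounds shown here alone, is whether the same change on the open-chain compound 1 would give a step of similar size in this assay.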